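Swapping methyl for fluoro on a retinoid carboxylic acid

The compounds below may be only part of what the source reports. "The series", "measured", "known", "first", "only" and "open" are said of these compounds alone.

Of the compounds shown here, three share one core and have been measured in an assay on isolated protein with retinoic acid receptor alpha (Homo sapiens) as the target; a lower number here means a smaller maximal response, a higher number a larger maximal response. Compound 1 `CC1(C)CCC(C)(C)c2c1cc(O)c(C(=O)c1ccc3cc(C(=O)O)ccc3c1)c2F` gives 46%, compound 2 `CC1(C)CCC(C)(C)c2cc(C(=O)c3ccc4cc(C(=O)O)ccc4c3)c(O)cc21` gives 44%, and compound 3 `Cc1cc2c(cc1C(=O)c1ccc3cc(C(=O)O)ccc3c1)C(C)(C)CCC2(C)C` gives 26%. Compound 3 therefore stands lowest of the three, with compound 2 nearest and compound 1 furthest, both beyond the scatter.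

Compound 4 `CC1(C)CCC(C)(C)c2cc(C(=O)c3ccc4cc(C(=O)O)ccc4c3)c(F)cc21` has not been measured yet. It differs from compound 3 in one place: fluoro in place of methyl on an aromatic carbon.

For the measured compounds named here, no measured step exchanges fluoro for methyl directly, so two neighbouring steps must serve. The step of a number 2 percentage points lower from compound 1 to compound 2 (within the scatter) shows that fluoro against hydrogen, on a different carbon of the core, makes no difference beyond the scatter. The step of a number 18 percentage points lower from compound 2 to compound 3 (beyond the scatter) shows a modest fall when methyl replaces hydroxy at the very carbon that now changes. Compound 4 carries fluoro there and resembles compound 2 more than compound 3 does, so a modest rise is expected, of about a number 8 percentage points higher from compound 3 to compound 4 (within the scatter).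

Compound 4 is thus expected to give about 34%, within a range from 22% to 46%.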

Compound 4, largest response reached (reported as maximum), in percent of the reference or control that the assay uses: 34%
Beside the measured number, compound 4's estimate shows no gap at the digits printed, and the stated range covers the measured number.
By their numbers in this assay, from the lowest: compounds 3, 4, 2 and 1 (each within the scatter of the next, the first and the last beyond it).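

Putting fluoro in place of methyl on this aromatic carbon in this assay gives a number 8 percentage points higher from compound 3 to compound 4 (within the scatter) while putting fluoro in place of hydroxy on the same carbon gives a number 10 percentage points lower from compound 2 to compound 4 (within the scatter) and so neither exchange can be told from repeat-measurement noise. Compound 2 and compound 3 are separated beyond the scatter, yet compound 4 cannot be separated from either one, so fluoro here cannot be grouped firmly with hydroxy or with methyl. No measurement in hand explains why the group on this carbon affects the maximal response.

On these data alone, whether an amine, a chloro group or a methoxy group on this carbon would track hydroxy or methyl remains open. Also open, as far as these compounds go, is whether fluoro here would give a similar response on a core that also carries the second fluoro of compound 1.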